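Notes on the aryl group on the aromatic nitrogen

The source may report more compounds than this note shows. Statements on the series, on what has been measured and on what is new or still open speak of the compounds shown alone.

Measured so far:
compound 1 `Cc1ccccc1-n1nncc1CN1C(=O)C2(C(C#N)=C(N)Oc3c(N)cc4nc5ccccc5nc4c32)c2ccccc21` — in an ADME assay on HUVEC cells (Homo sapiens) for antiproliferative activity, read by MTT assay, with a stated time of 48 h (a higher number here means a weaker inhibitor, a lower number a stronger inhibitor), compound 1 gives > 50000 nM, a limit of the assay.
compound 2 `CCc1cccc(CC)c1-n1nncc1CN1C(=O)C2(C(C#N)=C(N)Oc3c(N)cc4nc5ccccc5nc4c32)c2ccccc21` — in this assay compound 2 gives > 50000 nM, a limit of the assay.

Compound 2 stands at the limit of this assay with > 50000 nM, which is not a number. For the measured compounds named here, the one further value shown sits at the same limit, as the limit of > 50000 nM in this assay, at which 2 of the 2 values shown sit, records. Going by the values given here, the only step between measured compounds, a step that the two limits leave unreadable from compound 1 to compound 2, is therefore unreadable in size, with 2,6-diethylphenyl in place of 2-methylphenyl on an aromatic nitrogen.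

Compound 3 `N#CC1=C(N)Oc2c(N)cc3nc4ccccc4nc3c2C12C(=O)N(Cc1cnnn1-c1c(Cl)cc(Cl)cc1Cl)c1ccccc12` has not yet been measured. Its difference from compound 2 is 2,4,6-trichlorophenyl in place of 2,6-diethylphenyl on an aromatic nitrogen. Among the compounds with values here, the only step that bears on it is the unreadable one from compound 1 to compound 2, so no size in either direction can be drawn from it. Compound 3 is accordingly expected to remain at the limit, with an estimate of 50000 nM and a range from 20000 nM to 120000 nM. The expected step is a number no higher from compound 2 to compound 3 (the limit leaves the size open).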

Compound 3, half-maximal inhibitory concentration: 18300 nM
Beside the measured number, compound 3's estimate is 2.7-fold (0.44 log units) above it; measured number below the stated range.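

In this assay, the aryl group on the aromatic nitrogen can bring the number off the limit: 2,4,6-trichlorophenyl gives an at least 2.7-fold lower number from compound 2 to compound 3 (0.43 log units; beyond the scatter), and against 2-methylphenyl it gives an at least 2.7-fold lower number from compound 1 to compound 3 (0.43 log units; beyond the scatter). Both sizes are minimums, because each step starts from a limit of the assay: the limit of > 50000 nM in this assay, at which 2 of the 3 values shown sit. The step between the two limit compounds cannot be read, so 2-methylphenyl and 2,6-diethylphenyl cannot be placed in any order, and only the 2,4,6-trichlorophenyl group gives a number at this position.

The compounds shown leave open whether the chlorine atoms themselves carry this step or whether any aryl group with three substituents would do the same. An unsubstituted phenyl or a 2,4,6-trifluorophenyl group at this position would help separate these two readings.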